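Adding chloro to the strongest of three compounds

The source may report more compounds than this note shows. Statements on the series, on what has been measured and on what is new or still open speak of the compounds shown alone.

Compound 1 `CCN(CC)CN1C(=O)/C(=N/NC(=S)Nc2ccccc2)c2cc(Cl)ccc21` gives 34000 nM
Compound 2 `CCN(CC)CN1C(=O)/C(=N/NC(N)=S)c2cc(Cl)ccc21` gives 44000 nM
Compound 3 `CCN(CC)CN1C(=O)/C(=N/NC(=S)Nc2ccc(OC)cc2)c2ccccc21` gives 4400 nM

In a functional assay on HeLa cells (Homo sapiens) for inhibition, read by cell counting, with a stated time of 96 h (a higher number here means a weaker inhibitor, a lower number a stronger inhibitor), compound 3 has the lowest number of the three, clearly apart from both others, which makes it the strongest inhibitor so far. Compound 4 `CCN(CC)CN1C(=O)/C(=N/NC(=S)Nc2ccc(OC)cc2)c2cc(Cl)ccc21` is compound 3 with chloro in place of hydrogen on an aromatic carbon.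

Going by the values given here, no measured step isolates this change. The only one, a 1.3-fold higher number from compound 1 to compound 2 (0.11 log units; within the scatter), is hydrogen in place of phenyl on an amide-type nitrogen, so it bears only indirectly: among the chloro compounds, removing that phenyl made no clear difference. Compound 1 does carry the chloro and stands at 34000 nM, but it also lacks the methoxy of compound 3, so its gap to compound 3 cannot be pinned on chloro alone. A moderate rise in the number, meaning a weaker inhibitor, therefore seems likely, though the evidence is thin. The expected change is a 3.0-fold higher number from compound 3 to compound 4 (0.47 log units; beyond the scatter). Compound 4 is estimated at 13000 nM, with an expected range from 3500 nM to 45000 nM.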

Compound 4, half-maximal inhibitory concentration: 9200 nM
Compound 4: the middle estimate sits 1.4-fold (0.15 log units) above what was measured; the range from low to high includes it.
By their numbers in this assay, from the lowest: compound 3; then compound 4; then compounds 1 and 2 (each within the scatter of the next).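

In this assay, chloro in place of hydrogen on an aromatic carbon of the fused system now has a step of its own, and it gives a modest loss of strength: a 2.1-fold higher number from compound 3 to compound 4 (0.32 log units; beyond the scatter). With chloro kept, the methoxy still counts, as shown by a 3.7-fold lower number from compound 1 to compound 4 (0.57 log units; beyond the scatter) and by a 4.8-fold lower number from compound 2 to compound 4 (0.68 log units; beyond the scatter), while compound 1 and compound 2 stay within the scatter of each other (a 1.3-fold higher number from compound 1 to compound 2 (0.11 log units; within the scatter)). Nothing available accounts for the size or direction of these steps.

Going by these compounds alone, only one matched pair carries the chloro step, so it remains open whether the step would be the same with a different group on the amide-type nitrogen. Also open, going by these compounds, is how fluoro or bromo would compare with chloro here, or how ethoxy or an amine would compare with the methoxy.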